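The compounds below may be only part of what the source reports. "The series", "measured", "known", "first", "only" and "open" are said of these compounds alone.

Compound 1 `c1cnc(-c2ccccc2OCC2=NCCN2)nc1` is the reference point of this pair. In a functional assay for activation of Alpha-1B adrenergic receptor (Homo sapiens), read by calcium flux (on this read-out higher numbers stand for an effect only at larger amounts of compound and lower numbers for an effect already at smaller amounts), compound 1 gives < 100000 nM, which is a limit of the assay rather than a number. Compound 2 `c1csc(-c2ccccc2OCC2=NCCN2)c1` carries thiophen-2-yl where compound 1 carries pyrimidin-2-yl. In this assay compound 2 gives 3.98 nM. The step that the limit leaves unreadable from compound 1 to compound 2 cannot be sized, since the limit of < 100000 nM in this assay, at which 1 of the 2 values shown sits, leaves one end open. Compound 3 `Cc1ccoc1-c1ccccc1OCC1=NCCN1` is not yet measured. Its change from compound 1 is 3-methylfuran-2-yl in place of pyrimidin-2-yl on an aromatic carbon. For the measured compounds named here, the only measured step that bears on it is the one from compound 1 to compound 2, which also replaces pyrimidin-2-yl with a five-membered aromatic ring and ends at a potent value, though its size is unreadable. The same direction is expected here, toward a potent value. The expected step in this assay is a step that the limit leaves unreadable from compound 1 to compound 3. Compound 3 is estimated to give 10 nM, within 1 nM to 100 nM.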

Compound 3, half-maximal effective concentration: < 100000 nM
Compound 3: only a limit was reported; the forecaster's own chance of this, stated with the estimate: 5%; the middle value lies beyond the limit too.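

No step from compound 1 or compound 2 to compound 3 can be read in this assay, as compound 3 also rests on a limit: the limit of < 100000 nM in this assay, at which 2 of the 3 values shown sit.

The compounds shown leave open how far 3-methylfuran-2-yl and thiophen-2-yl truly differ from pyrimidin-2-yl, or from each other.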